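The source may report more compounds than this note shows. Statements on the series, on what has been measured and on what is new or still open speak of the compounds shown alone.

Three compounds share one core and differ only in the aryl group on the amine nitrogen in the ring. In a functional assay on CHO cells with adenosine receptor A1 (Homo sapiens) as the target, read by cAMP accumulation and immunoassay, with a stated time of 6 min, tested at 0.01 uM (a lower number here means a stronger effect, a higher number a weaker effect of the compound at the concentration tested), compound 1 `Nc1scc(CN2CCN(c3cccc(Cl)c3Cl)CC2)c1C(=O)c1ccc(Cl)cc1` gives 1%, compound 2 `Nc1scc(CN2CCN(c3cc(Cl)cc(Cl)c3)CC2)c1C(=O)c1ccc(Cl)cc1` gives -1%, and compound 3 `Nc1scc(CN2CCN(c3cccc(C(F)(F)F)c3)CC2)c1C(=O)c1ccc(Cl)cc1` gives -8.2%. Compound 3 carries numerically the smallest of the three numbers, yet a number 9.2 percentage points lower from compound 1 to compound 3 (within the scatter) and a number 7.2 percentage points lower from compound 2 to compound 3 (within the scatter) lie within the scatter, as does a number 2 percentage points lower from compound 1 to compound 2 (within the scatter). Compound 4 `Nc1scc(CN2CCN(c3c(F)cccc3F)CC2)c1C(=O)c1ccc(Cl)cc1` has not yet been measured; it differs from compound 3 by 2,6-difluorophenyl in place of 3-(trifluoromethyl)phenyl on an amine nitrogen in a ring. Compound 4 is expected to show a number 5.2 percentage points higher from compound 3 to compound 4 (within the scatter), since every earlier exchange of this aryl group gave a number 2 percentage points lower from compound 1 to compound 2 (within the scatter), a number 9.2 percentage points lower from compound 1 to compound 3 (within the scatter) or a number 7.2 percentage points lower from compound 2 to compound 3 (within the scatter), none beyond the scatter. Compound 4 is therefore estimated at -3% in this assay, within -15% to 9%.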

Compound 4, a percentage reported as activity, at one concentration (the size of the read-out at that concentration, not a potency): -12%
Compound 4: middle estimate off by 9 percentage points, on the high side, and the stated range covers the measured number.
By their numbers in this assay, from the lowest: compounds 4, 3, 2 and 1 (each within the scatter of the next, the first and the last beyond it).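

In this assay the aryl group on the amine nitrogen in a ring now yields steps beyond the scatter, with a number 11 percentage points lower from compound 2 to compound 4 (beyond the scatter) and a number 13 percentage points lower from compound 1 to compound 4 (beyond the scatter) as modest changes, while a number 3.8 percentage points lower from compound 3 to compound 4 (within the scatter) stays within it. The position therefore responds to this exchange, though 2,6-difluorophenyl and 3-(trifluoromethyl)phenyl cannot be told apart here. Nothing available explains these steps. 

Open, as far as these compounds go, is whether a methoxy group or an amine on this phenyl ring would extend the steps. Also open, from the compounds shown here alone, is how a plain unsubstituted phenyl or a saturated cyclohexyl group would compare.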